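The compounds below may be only part of what the source reports. "The series", "measured", "known", "first", "only" and "open" are said of these compounds alone.

Measured compounds:

Compound 1 `Nc1nc(-c2ccccc2)nc2sc(-c3ccccc3)nc12` gives 84 nM in an assay on CHO cells for displacement of a labelled ligand from adenosine receptor A3 (Homo sapiens), read by scintillation counting, with a stated time of 3 h; on this read-out higher numbers stand for weaker inhibition and lower numbers for stronger inhibition.
Compound 2 `Nc1nc(-c2ccc(CO)cc2)nc2sc(-c3ccccc3)nc12` gives 8.2 nM in this assay.
Compound 3 `N#Cc1cccc(-c2nc(N)c3nc(-c4ccccc4)sc3n2)c1` gives 247 nM in this assay.

Compound 3 has the highest number of the three, so it is the weakest binder of the set. Its nearest neighbour is compound 1: a 2.9-fold higher number from compound 1 to compound 3 (0.47 log units; beyond the scatter). The gap to compound 2 is wider: a 30-fold higher number from compound 2 to compound 3 (1.48 log units; beyond the scatter).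

Compound 4 `N#Cc1cccc(-c2nc(N)c3nc(-c4ccco4)sc3n2)c1` has not yet been measured. It keeps the shared core and the 3-cyanophenyl group of compound 3, and changes only the other substituent: furan-2-yl in place of phenyl on an aromatic carbon.

For the measured compounds named here, none of the measured steps touches this position. All three steps between compounds 1, 2 and 3 alter the group on the opposite side of the core (a 10-fold lower number from compound 1 to compound 2 (1.01 log units; beyond the scatter); a 2.9-fold higher number from compound 1 to compound 3 (0.47 log units; beyond the scatter); a 30-fold higher number from compound 2 to compound 3 (1.48 log units; beyond the scatter)), while the phenyl on the five-membered ring stays fixed throughout. Going by the values given here, there is therefore no measured step from which the size or direction of the change in this assay can be read off.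

Among the compounds with values here, with no direct precedent, the expectation for compound 4 is a number close to that of compound 3, with a broad range either way: a 1.2-fold higher number from compound 3 to compound 4 (0.08 log units; within the scatter). The estimate for compound 4 is 300 nM, expected to fall between 80 nM and 1200 nM.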

Compound 4, inhibition constant: 61.5 nM
Estimate against measurement, compound 4: 4.9-fold (0.69 log units) above; measured number below the stated range.
By their numbers in this assay, from the lowest: compound 2; then compounds 4 and 1 (each within the scatter of the next); then compound 3.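

The phenyl on the five-membered ring stayed fixed through compounds 1 to 3, so only this result shows that this carbon, next to the ring nitrogen and the ring sulfur, also affects binding in this assay: furan-2-yl in place of phenyl gives a 4.0-fold lower number from compound 3 to compound 4 (0.60 log units; beyond the scatter). The step is modest, but it shows that a six-membered aromatic ring of carbon only is not required here, since a five-membered aromatic ring with 1 hetero atom, the oxygen, gives a lower number in this setting. The data shown offer no explanation for why the number falls with this swap.

From the compounds shown here alone, this is a single pair carrying the 3-cyanophenyl group, so it remains open whether furan-2-yl would lower the number to a similar degree alongside the 4-(hydroxymethyl)phenyl group of compound 2. Going by these compounds, it is also open whether the gain depends on the oxygen or on the smaller ring, a question that thiophene-2-yl, with sulfur in the ring, or a pyridine ring or a simple amine on the same carbon could help to answer.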